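Benzyl Ether to Fluorophenyl Ether on a Shared Core

The source may hold more compounds than are shown below. What is called first, only, known or untested is meant among the compounds shown, and "the series" means these compounds.

Of the compounds shown here, three have been measured in an in vitro assay on SH-EP1 cells for displacement of a labelled ligand from Neuronal acetylcholine receptor; alpha4/beta2 (Homo sapiens); a higher number here means a weaker inhibitor, a lower number a stronger inhibitor. Compound 1 `C1=C(c2cncc(OCc3ccccc3)c2)CC2CNCC1C2` gives 0.7 nM. Compound 3 `C1=C(c2cnccn2)CC2CNCC1C2` gives 1.1 nM, which lies within the scatter of compound 1. Compound 2 `CN1CC2C=C(c3ccc(F)nc3)CC(C2)C1` gives 18 nM, a number well beyond the scatter from compound 1. Compound 1 therefore stands at the lowest number of the three, yet it is not separated from compound 3.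

Compound 4 `Fc1ccc(Oc2cncc(C3=CC4CNCC(C3)C4)c2)cc1` has not been measured. It differs from compound 1 in one place: 4-fluorophenyl in place of benzyl on an oxygen on an aromatic ring. For the measured compounds named here, no measured pair shows this change, so its effect is not known from these data. The step of a 2.9-fold higher number from compound 1 to compound 4 (0.46 log units; beyond the scatter) is expected to be small, toward a weaker inhibitor, and may not exceed the scatter. Compound 4 is estimated in this assay at 2 nM, within 0.5 nM to 8 nM.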

Compound 4, inhibition constant: 0.6 nM
Beside the measured number, compound 4's estimate is 3.3-fold (0.52 log units) above it, within the range that was stated.
By their numbers in this assay, from the lowest: compounds 4, 1 and 3 (each within the scatter of the next); then compound 2.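

In this assay, 4-fluorophenyl in place of benzyl on an oxygen on an aromatic ring gives a 1.2-fold lower number from compound 1 to compound 4 (0.07 log units; within the scatter), so this position takes either group without a readable change in the number. For the compounds shown here, this is the first measured pair showing the change, and the two groups match in their count of heavy atoms and in their single aromatic ring of carbon only. Nothing available here accounts for this result.
Still open, going by these compounds, is how an unsubstituted phenyl ether or a phenethyl ether would read at this oxygen, and whether an amine on the phenyl ring would leave the number unchanged.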